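The source may hold more compounds than are shown below. What is called first, only, known or untested is meant among the compounds shown, and "the series" means these compounds.

Compound 1, `CCOc1ccc(-c2nc(-c3ccc(CCC(=O)O)cc3C)no2)cc1C(F)(F)F`: 260 nM
Compound 2, `Cc1cc(CCC(=O)O)ccc1-c1noc(-c2ccc(OC(C)C)c(Br)c2)n1`: 43 nM
Compound 3, `CCCCc1ccc(-c2nc(-c3ccc(CCC(=O)O)cc3C)no2)nc1`: > 10000 nM

Three compounds that share a common core were tested in a functional assay on CHO cells for agonist activity at sphingosine 1-phosphate receptor 5 (Homo sapiens), read by GTPgammaS binding; on this read-out higher numbers stand for an effect only at larger amounts of compound and lower numbers for an effect already at smaller amounts. Compound 1 gives 260 nM and compound 2 gives 43 nM, so both produce a response at measurable amounts. Compound 3 stands apart. For compound 3 the result > 10000 nM is a limit of the assay rather than a measured number. Among the values shown, compound 3 therefore sits at the limit of > 10000 nM in this assay, at which 1 of the 3 values shown sits, the point past which no effect could be recorded.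

The next compound, compound 4, `Cc1cc(CCC(=O)O)ccc1-c1noc(-c2ccc(CC(C)C)cn2)n1`, has not yet been measured. It differs from compound 3 only in the shape of one side chain: isopropyl in place of propyl on a saturated chain carbon bound to an aromatic carbon. The same atoms are present, only joined differently, so the two structures are isomers.

Within the data shown here, no measured pair in this set shows what such a rearrangement does, so the expected step is small. Since compound 3 already reached the limit of this assay, the most likely outcome for compound 4 is again a limit, and the step of a number no higher from compound 3 to compound 4 (the limit leaves the size open) is expected to stay within the usual scatter. Compound 4 is accordingly estimated at 10000 nM, with a range from 3000 nM to 30000 nM.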

Compound 4, half-maximal effective concentration: > 1000 nM
Compound 4: a limit, no number (the forecaster's own chance of this, stated with the estimate: 75%); the middle value does not contradict the limit.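

In this assay compound 3 gives > 10000 nM, which is a limit and not a number. Compound 4 gives > 1000 nM, again a limit. Among these compounds, no step from one to the other can therefore be read. The compounds shown leave open whether isopropyl in place of propyl changes the response at all.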